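The source may report more compounds than this note shows. Statements on the series, on what has been measured and on what is new or still open speak of the compounds shown alone.

Measured compounds: compound 1 `Nc1nc(NCc2ccccc2)nc(-c2ccccc2CO)n1` gives 4.35; compound 2 `CN(C)c1nc(NCc2ccccc2)nc(-c2ccccc2CO)n1` is reported as "not active" (no number reported); compound 3 `COc1ccc(CO)c(-c2nc(N)nc(NCc3ccccc3)n2)c1` gives 3.99.

All three share the same core and were tested in a functional assay on cells for positive allosteric modulation of G-protein coupled receptor 68 (Homo sapiens), read by a luciferase reporter and cAMP accumulation, with a stated time of 30 min, at pH 6.8 and pH 8.3, in the presence of a further agent that is not named here; on this read-out lower numbers stand for lower potency and higher numbers for higher potency (the scale is a negative logarithm). Among the two numbers, compound 1 stands highest, and compound 3 lies nearest to it, reached by the single change of methoxy in place of hydrogen on an aromatic carbon; that step is a number 0.36 log units lower from compound 1 to compound 3 (beyond the scatter). Compound 2 carries a dimethylamino group in place of the amino group and gave no number at all.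

Compound 4 `Nc1nc(Nc2ccccc2)nc(-c2ccccc2CO)n1` has not been measured. It differs from compound 1 in one place: phenyl in place of benzyl on a nitrogen on an aromatic ring. For the measured compounds named here, no measured step touches the group on that nitrogen, so the only guidance is that the one measured change elsewhere on the scaffold, from compound 1 to compound 3, cost a modest amount and that the series runs at low potency overall. On that basis compound 4 is expected to land near or somewhat under compound 1, a step of a number 0.25 log units lower from compound 1 to compound 4 (within the scatter). The estimate for compound 4 is 4.1, with a range from 3.5 to 4.6.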

Compound 4, negative logarithm of the antagonist equilibrium constant: 3.92
Beside the measured number, compound 4's estimate is 0.18 log units above it; measured number inside the range.
By their numbers in this assay, from the lowest: compounds 4 and 3 (each within the scatter of the next); then compound 1.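

For the compounds shown here, changing the group on this nitrogen moves the read-out: the swap of benzyl for phenyl gives a number 0.43 log units lower from compound 1 to compound 4 (beyond the scatter), and it is the first measured step at this position. The change is small, since benzyl has 7 heavy atoms and phenyl has 6, and both hold the same six-membered aromatic ring of carbon only, so even this slight trimming of the group has a visible effect. Nothing measured here explains why the number falls with this swap.

Going by these compounds, it remains open whether a longer chain, such as 2-phenylethyl, on this nitrogen would continue the trend from phenyl to benzyl or reverse it. Also open, on these data alone, is how a chlorine or a methoxy group on the benzyl ring, or a pyridine ring in its place, would affect the number.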